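From Ethyl(methyl)amino to Isopropylamino: An Estimate

The compounds below may be only part of what the source reports. "The series", "measured", "known", "first", "only" and "open" are said of these compounds alone.

Measured compounds and their values:
compound 1 `N=C(NC(=N)NC1CCCC1)Nc1ccc(C(F)(F)F)cc1` — in a functional assay on T-24 cells (Homo sapiens) for antiproliferative activity, read by MTT assay, with a stated time of 72 h (on this read-out lower numbers stand for stronger inhibition and higher numbers for weaker inhibition), compound 1 gives 3700 nM
compound 2 `CCN(C)C(=N)NC(=N)Nc1ccc(C(F)(F)F)cc1` — compound 2 gives 5700 nM
compound 3 `CCCCCCCNC(=N)NC(=N)Nc1ccc(F)c(F)c1` — compound 3 gives 4300 nM

Compound 2 sits at the top end of these three numbers, but its gaps to compound 3 and to compound 1 both fall within the usual scatter of this kind of measurement, so the three compounds cannot be told apart on the data shown.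

Compound 4 `CC(C)NC(=N)NC(=N)Nc1ccc(C(F)(F)F)cc1` has not yet been measured. It differs from compound 2 by isopropylamino in place of ethyl(methyl)amino on a carbon with a double bond to nitrogen. Going by the values given here, the one measured step that bears on this change is the step from compound 1 to compound 2, which replaced cyclopentylamino by ethyl(methyl)amino on the same carbon and gave a 1.5-fold higher number from compound 1 to compound 2 (0.19 log units; within the scatter). That swap between one amino group and another moved the number only within the scatter, so the present swap is expected to do much the same: no step beyond the scatter, perhaps a small drift back toward the number of compound 1.

Compound 4 is therefore estimated at 4500 nM, with a range of 2200 nM to 9000 nM. The step this estimate implies is a 1.3-fold lower number from compound 2 to compound 4 (0.10 log units; within the scatter).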

Compound 4, half-maximal inhibitory concentration: 4800 nM
Compound 4: middle estimate off by 1.1-fold (0.03 log units), on the low side; the range from low to high includes it.
By their numbers in this assay, from the lowest: compounds 1, 3, 4 and 2 (each within the scatter of the next).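

Swapping ethyl(methyl)amino for isopropylamino on the carbon with a double bond to nitrogen keeps the same atoms, joined differently, yet the entering group carries a hydrogen-bond donor that the leaving group lacks. In this assay, going by these compounds alone, this swap gives a 1.2-fold lower number from compound 2 to compound 4 (0.07 log units; within the scatter), so adding that donor at this position produces no step that can be read. Replacing the cyclopentyl ring with open isopropyl on the amine nitrogen gives a 1.3-fold higher number from compound 1 to compound 4 (0.11 log units; within the scatter), so cyclopentylamino, ethyl(methyl)amino and isopropylamino cannot be told apart here.

On these data alone, whether a much larger or differently built group at this place, such as a benzylamine or a carboxylic acid, would move the number beyond the scatter remains open. No measurement at hand offers an explanation for how these compounds act on the cells.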